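Removing one methoxy group from a chalcone-type pyrazole

This account rests on a few compounds, and the source may have more. Where it says the series, first, only, none or still open, it means among the compounds named here.

Measured compounds:
compound 1 `COc1cc(-c2cc(/C=C/C(=O)c3ccc(N)cc3)[nH]n2)cc(OC)c1OC`: 107%
compound 2 `COc1ccc(C(=O)/C=C/c2cc(-c3cc(OC)c(OC)c(OC)c3)n[nH]2)cc1OC`: 98%

In a functional assay on IGROV-1 cells (Homo sapiens) for cytotoxicity, read by sulforhodamine B assay, with a stated time of 48 h, tested at 0.01 uM (a lower number here means a stronger effect, a higher number a weaker effect of the compound at the concentration tested), compound 2 gives 98%, the lower of the two numbers available, with compound 1 nearest at 107%. Among the measured compounds shown here, the one measured step, a number 9 percentage points lower from compound 1 to compound 2 (within the scatter), altered the aryl group on the carbonyl carbon and stayed within the scatter. Compound 3 `COc1ccc(C(=O)/C=C/c2cc(-c3cc(OC)c(OC)c(OC)c3)n[nH]2)cc1` is reached by a smaller change at the same ring: hydrogen in place of methoxy on an aromatic carbon. For the measured compounds named here, since the only step touching this ring produced no shift beyond the scatter, and since both measured numbers sit close to the level of untreated cells, no step beyond the scatter is expected here either. The account therefore expects the step of a number 2 percentage points higher from compound 2 to compound 3 (within the scatter) to be small. For compound 3 in this assay a value of 100% is estimated, with a range from 85% to 115%.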

Compound 3, a percentage reported as activity, at one concentration (the size of the read-out at that concentration, not a potency): 101%
Beside the measured number, compound 3's estimate is 1 percentage points below it; measured number inside the range.
By their numbers in this assay, from the lowest: compounds 2, 3 and 1 (each within the scatter of the next).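

Taking one methoxy group off the ring on the carbonyl carbon, the change from 3,4-dimethoxyphenyl to 4-methoxyphenyl, gives a number 3 percentage points higher from compound 2 to compound 3 (within the scatter) in this assay and is the first step here that alters only this one position. The other new comparison, with methoxy in place of amino on an aromatic carbon, gives a number 6 percentage points lower from compound 1 to compound 3 (within the scatter) and shows that the group at this same ring can be exchanged with no step beyond the scatter, so 4-aminophenyl, 3,4-dimethoxyphenyl and 4-methoxyphenyl do not separate at the concentration tested. No supporting data bear on this result.

As far as these compounds go, whether a hydroxyl group, a carboxylic acid or a longer alkoxy chain on this ring would read any differently remains open. Also open, from the compounds shown here alone, is whether these three compounds would separate at a higher concentration, since a single low concentration gives no measure of potency.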